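Lengthening the ester chain on a chlorinated core

A few compounds are considered here, and "the series" means these few. Any claim that something is new, unique, unknown or untested is made for them only; others in the source may bear on it.

Measured compounds:
Compound 1, `CCOC(=O)CCCSc1nc2cc(-n3nc(C(C)(C)C)sc3=O)c(F)cc2s1`: 8670 nM
Compound 2, `CCOC(=O)CCSc1nc2cc(-n3nc(C(C)(C)C)sc3=O)c(Cl)cc2s1`: 1280 nM

Both compounds were tested in an assay on isolated protein for inhibition of protoporphyrinogen oxidase (Homo sapiens), read by capillary electrophoresis; on this read-out higher numbers stand for weaker inhibition and lower numbers for stronger inhibition. Compound 2 gives the lower of the two numbers, and compound 1 sits well beyond the usual scatter above it. Among the measured compounds shown here, the two compounds differ in two places at once, so their values show only that the pair as a whole lands far apart; nothing tells how much of that gap belongs to each change.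

Compound 3, `CCOC(=O)CCCSc1nc2cc(-n3nc(C(C)(C)C)sc3=O)c(Cl)cc2s1`, has not yet been measured in this assay. It keeps the chlorine of compound 2 and changes only the chain that carries the ester: (ethoxycarbonyl)methyl in place of ethoxycarbonyl on a saturated chain carbon, two bonds along the chain from a sulfur. In plain terms, one more saturated carbon is inserted into the link between the sulfur and the ester.

For the measured compounds named here, there is no measured pair in this set that isolates that chain extension. Compound 1, which carries the longer chain together with a fluorine, shows a markedly higher number than compound 2, so some weakening is a reasonable expectation, though its size is uncertain. The step from compound 2 to compound 3 is expected to be a 2.3-fold higher number from compound 2 to compound 3 (0.37 log units; beyond the scatter), a moderate loss. Compound 3 is therefore estimated at 3000 nM, within a range from 1000 nM to 9000 nM.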

Compound 3, inhibition constant: 17700 nM
The estimate for compound 3 lay 5.9-fold (0.77 log units) below the measured number; measured number above the stated range.
By their numbers in this assay, from the lowest: compound 2; then compound 1; then compound 3.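

In this assay, lengthening (2-(ethoxycarbonyl)ethyl)sulfanyl to (3-(ethoxycarbonyl)propyl)sulfanyl with the chlorine held constant gives a 14-fold higher number from compound 2 to compound 3 (1.14 log units; beyond the scatter), a large loss, so this chain is far from indifferent to a single added saturated carbon. With the longer chain held constant, the halogen has a smaller but still real effect: a 2.0-fold higher number from compound 1 to compound 3 (0.31 log units; beyond the scatter) accompanies chloro in place of fluoro on the aromatic carbon, a modest step that still lies beyond the usual scatter, so fluoro gives the lower number on this chain. Nothing shown here explains why either change moves the number as it does.

A shorter chain, with (ethoxycarbonyl)methyl on the sulfur, would show whether the number keeps falling as the chain shortens or whether the 2-(ethoxycarbonyl)ethyl length is the best of the series, and fluoro on that same 2-(ethoxycarbonyl)ethyl chain would show whether the halogen step keeps its direction there. Going by these compounds, it also remains open how a carboxylic acid or an amide in place of the ethyl ester would read at either chain length.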